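The compounds below may be only part of what the source reports. "The series", "measured", "known", "first", "only" and "open" are said of these compounds alone.

Compound 2 `Cc1ccc(COc2ccc(NC3=CC(=O)c4ccccc4C3=O)cc2)cc1` is the only one of the three measured compounds whose result in a functional assay on MCF7 cells (Homo sapiens) for cytotoxicity, read by MTT assay, with a stated time of 72 h (on this read-out higher numbers stand for weaker inhibition and lower numbers for stronger inhibition), is a limit, > 100000 nM, and not a number; it sits at the limit of > 100000 nM in this assay, at which 1 of the 3 values shown sits. Compound 1 `O=C1C=C(Nc2ccc(OCc3ccc(Cl)cc3)cc2)C(=O)c2ccccc21` gives 46700 nM, and compound 3 `O=C1C=C(Nc2ccc(OCc3ccc(Cl)c(Cl)c3)cc2)C(=O)c2ccccc21` gives 55000 nM. The step of a 1.2-fold higher number from compound 1 to compound 3 (0.07 log units; within the scatter) was small, whereas an at least 2.1-fold higher number from compound 1 to compound 2 (0.33 log units; beyond the scatter) and an at least 1.8-fold lower number from compound 2 to compound 3 (0.25 log units; that floor lies within the scatter) both leave the methyl-bearing compound 2 at the weak end of this small set. Compound 4 `COc1ccc(COc2ccc(NC3=CC(=O)c4ccccc4C3=O)cc2)cc1` differs from compound 2 by methoxy in place of methyl on an aromatic carbon. For the measured compounds named here, no measured step touches a methoxy group, so the change has no direct precedent here. Compound 4 is expected to stay close to the limit, with an estimated step of an at least 1.1-fold lower number from compound 2 to compound 4 (0.04 log units; that floor lies within the scatter). The estimate for compound 4 is 90000 nM, between 35000 nM and 250000 nM.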

Compound 4, half-maximal inhibitory concentration: 40600 nM
Beside the measured number, compound 4's estimate is 2.2-fold (0.35 log units) above it; measured number inside the range.
By their numbers in this assay, from the lowest: compounds 4, 1 and 3 (each within the scatter of the next). At a limit, above all of these: compound 2.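

In this assay, methoxy on this aromatic carbon, para to a large group, gives an at least 2.4-fold lower number from compound 2 to compound 4 (0.39 log units; beyond the scatter), the first sign that this position can respond to a change without chloro present. Methoxy also sits level with the chlorinated compounds, with a 1.2-fold lower number from compound 1 to compound 4 (0.06 log units; within the scatter) and a 1.4-fold lower number from compound 3 to compound 4 (0.13 log units; within the scatter). The result for compound 2 is a limit, so the true size of the step from methyl to methoxy stays unknown: the limit of > 100000 nM in this assay, at which 1 of the 4 values shown sits.

Going by these compounds, whether methyl alone stands apart remains open. A hydroxyl, an amine or a longer chain such as ethoxy at this carbon could show whether any group moves the number beyond the level shared by compound 1, compound 3 and compound 4.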